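Benzyl ether variation and cytotoxicity in the anilinopyrimidine series

The source may report more compounds than this note shows. Statements on the series, on what has been measured and on what is new or still open speak of the compounds shown alone.

Measured compounds:
compound 1 `N#Cc1ccc(Nc2nccc(OCc3cccnc3)n2)cc1`: 6400 nM
compound 2 `N#Cc1ccc(Nc2nccc(OCc3cccc(Cl)c3)n2)cc1`: 153000 nM
compound 3 `COc1cccc(COc2ccnc(Nc3ccc(C#N)cc3)n2)c1`: 118000 nM

In an ADME assay on MT4 cells (Homo sapiens) for cytotoxicity, read by MTT assay, with a stated time of 5 days (a higher number here means that more compound is tolerated, a lower number that less compound is tolerated), compound 3 stands second highest of the three numbers. Its nearest neighbour is compound 2, with a 1.3-fold lower number from compound 2 to compound 3 (0.11 log units; within the scatter); the furthest is compound 1, with an 18-fold higher number from compound 1 to compound 3 (1.27 log units; beyond the scatter). The step from compound 1 to compound 2, a 24-fold higher number from compound 1 to compound 2 (1.38 log units; beyond the scatter), is of similar size. Going by the values given here, both large steps come with 3-chlorophenyl or 3-methoxyphenyl in place of pyridin-3-yl; the one step that keeps the phenyl and swaps only the substituent on it lies within the scatter.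

Compound 4 `N#Cc1ccc(Nc2nccc(OCc3ccccc3)n2)cc1` is not yet measured. The change: hydrogen in place of methoxy on an aromatic carbon. This stays on the phenyl ring, so the step from compound 2 to compound 3 is the one that bears on it, and it was within the scatter. A step of no more than the scatter is therefore expected in this assay, in no firm direction. For compound 4 the expected value is 100000 nM, range 40000 nM to 250000 nM, which is an estimated step of a 1.2-fold lower number from compound 3 to compound 4 (0.07 log units; within the scatter).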

Compound 4, half-maximal cytotoxic concentration: 13000 nM
Compound 4: the middle estimate sits 7.7-fold (0.89 log units) above what was measured; measured number below the stated range.
By their numbers in this assay, from the lowest: compound 1; then compound 4; then compounds 3 and 2 (each within the scatter of the next).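

In this assay the substituent on the phenyl ring proves not to be silent: hydrogen in place of methoxy gives a 9.1-fold lower number from compound 3 to compound 4 (0.96 log units; beyond the scatter) and hydrogen in place of chloro gives a 12-fold lower number from compound 2 to compound 4 (1.07 log units; beyond the scatter) as the two steps at this aromatic carbon, even though methoxy and chloro lie within the scatter of each other. Phenyl in place of pyridin-3-yl, taken alone, gives only a 2.0-fold higher number from compound 1 to compound 4 (0.31 log units; beyond the scatter) in this series, so most of the large earlier steps from compound 1 goes with the added methoxy or chloro and not with the exchange of pyridin-3-yl for a phenyl ring. No supporting measurement accompanies these steps, and they stand without an explanation.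

As far as these compounds go, whether any group at this aromatic carbon gives the same high number, or only methoxy and chloro do, remains open. A methyl, a fluoro, an amine or a carboxylic acid at the same place would test this.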